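Pyridinyl amide in a sulfonamide series at the chemokine receptor

The source may report more compounds than this note shows. Statements on the series, on what has been measured and on what is new or still open speak of the compounds shown alone.

The account concerns two measured compounds and one that is not yet measured. Compound 1 `Cc1ccccc1C(=O)NCc1ccc(CNS(=O)(=O)c2ccc(F)cc2)cc1` and compound 2 `COc1ccccc1C(=O)NCc1ccc(CNS(=O)(=O)c2ccc(F)cc2)cc1` share a core and differ in a single group. In an assay on MDA-MB-231 cells for displacement of a labelled ligand from C-X-C chemokine receptor type 4 (Homo sapiens), read by fluorescence and microscopy, with stated times of 10 min and 30 min (a lower number here means that less compound is needed, a higher number that more compound is needed for the effect), compound 1 gives 10 nM, and compound 2 gives 100 nM; the change is a 10-fold higher number from compound 1 to compound 2 (1.00 log units; beyond the scatter). Going by the values given here, compound 2 thus stands highest of the two numbers, with compound 1 as its only neighbour.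

Compound 3 `O=C(NCc1ccc(CNS(=O)(=O)c2ccc(F)cc2)cc1)c1cccnc1` is the unmeasured compound. Relative to compound 2 it carries pyridin-3-yl in place of 2-methoxyphenyl on a carbonyl carbon. Among the compounds with values here, the one measured step, the exchange of methyl for methoxy on the same carbonyl-bound ring, showed that this part of the molecule is sensitive, but it is not the same kind of change as replacing the whole ring by pyridin-3-yl, so no direction can be taken from it with confidence. The estimate for compound 3 in this assay is therefore placed near the value of compound 2, at 100 nM with a range from 25 nM to 400 nM, which corresponds to an expected no change at the digits printed from compound 2 to compound 3 (within the scatter).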

Compound 3, effective concentration (reported as EC, without a stated level of effect): 100 nM
Beside the measured number, compound 3's estimate shows no gap at the digits printed, within the range that was stated.
By their numbers in this assay, from the lowest: compound 1; then compounds 2 and 3 (each within the scatter of the next).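

In this assay, the exchange of the whole 2-methoxyphenyl group for pyridin-3-yl on a carbonyl carbon gives no change at the digits printed from compound 2 to compound 3 (within the scatter) so, for this pair, neither the methoxy group nor a ring of carbon only is needed to hold the number where it stands. Set against the 2-methylphenyl group, pyridin-3-yl gives a 10-fold higher number from compound 1 to compound 3 (1.00 log units; beyond the scatter) and that step matches in size the earlier 10-fold higher number from compound 1 to compound 2 (1.00 log units; beyond the scatter) so that, of the three groups on this carbonyl carbon, 2-methylphenyl alone stands apart with the lowest number, while two quite different rings share one level. Nothing given here explains why the 2-methylphenyl group stands apart from the other two.

On these data alone, it remains open whether an unsubstituted phenyl, pyridin-2-yl or pyridin-4-yl on the same carbonyl carbon would fall with compound 1 or with compounds 2 and 3, and so whether the low number belongs to the methyl group itself. Also open, as far as these compounds go, is how a chloro, an ethyl or an amine group on this ring would read in this assay and whether any such group would go lower than compound 1.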